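Amide Chain Variation and Cytotoxicity in One Cell Assay

The source may report more compounds than this note shows. Statements on the series, on what has been measured and on what is new or still open speak of the compounds shown alone.

Measured compounds:
compound 1 `O=C(CN1CCCC1)Nc1ccc(-c2nc3ccccc3[nH]2)cc1`: 70000 nM
compound 2 `CC(=O)Nc1ccc(-c2nc3ccccc3[nH]2)cc1`: > 100000 nM
compound 3 `CCC(=O)Nc1ccc(-c2nc3ccccc3[nH]2)cc1`: > 100000 nM

In an ADME assay on MDBK cells (Bos taurus) for cytotoxicity, read by MTT assay, with a stated time of 96 h (on this read-out higher numbers stand for lower toxicity in this test and lower numbers for higher toxicity in this test), compound 1 gives 70000 nM. For compound 2 the value > 100000 nM is a limit of the assay and not a number. For compound 3 the value > 100000 nM is likewise a limit of the assay. Compound 3 therefore stands at the limit of > 100000 nM in this assay, at which 2 of the 3 values shown sit, so its place on the numbers shown is known only as that boundary.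

The change to compound 4 `O=C(CN1CCCCC1)Nc1ccc(-c2nc3ccccc3[nH]2)cc1` is piperidin-1-yl in place of methyl on a saturated chain carbon bound to a carbonyl carbon. The measured steps that bear on it are an at least 1.4-fold higher number from compound 1 to compound 3 (0.15 log units; that floor lies within the scatter) and an at least 1.4-fold higher number from compound 1 to compound 2 (0.15 log units; that floor lies within the scatter), both of which end at a limit and so read only as floors that lie within the scatter. The step from compound 2 to compound 3, a step that the two limits leave unreadable from compound 2 to compound 3, gives no size. The reverse sense of that change is seen in the measured step of an at least 1.4-fold higher number from compound 1 to compound 3 (0.15 log units; that floor lies within the scatter), so for compound 4 a number near that of compound 1 is expected, with no step beyond the scatter readable. Compound 4 is expected to give 70000 nM in this assay, between 30000 nM and 160000 nM, which means an expected step of an at least 1.4-fold lower number from compound 3 to compound 4 (0.15 log units; that floor lies within the scatter).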

Compound 4, half-maximal cytotoxic concentration: 18000 nM
Beside the measured number, compound 4's estimate is 3.9-fold (0.59 log units) above it; measured number outside the range, below it.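

In this assay, piperidin-1-yl on a saturated chain carbon bound to a carbonyl carbon gives an at least 5.5-fold lower number from compound 3 to compound 4 (0.74 log units; beyond the scatter) and an at least 5.5-fold lower number from compound 2 to compound 4 (0.74 log units; beyond the scatter), so a change at this place is now seen to move the number beyond the scatter, which the floors reaching compound 1 did not show. The ring in this place also matters, for piperidin-1-yl in place of pyrrolidin-1-yl gives a 3.9-fold lower number from compound 1 to compound 4 (0.59 log units; beyond the scatter). The two larger steps read only as floors, as compound 2 and compound 3 each rest on a limit of the assay and not on a number: the limit of > 100000 nM in this assay, at which 2 of the 4 values shown sit.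

With only two rings at this place, the compounds shown leave open whether the number follows ring size or some other difference between the two rings. A morpholin-4-yl ring, with its added ring oxygen, or an open-chain dimethylamino group on the same carbon would bear on that question.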